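The source may hold more compounds than are shown below. What is called first, only, known or untested is meant among the compounds shown, and "the series" means these compounds.

The series rests on one shared core carrying a phenoxy-linked pyridine bearing a pyridyl group, to which different outer parts are attached. Compound 2 `Fc1ccc(Nc2cc(Nc3ccc(Oc4ccncc4-c4cccnc4)c(F)c3)ncn2)cc1` and compound 1 `Fc1ccc(Nc2cc(Nc3ccc(Oc4ccncc4-c4cccnc4)c(F)c3)ncn2)cc1F` were examined in a functional assay on MDA-MB-231 cells (Homo sapiens) for cytotoxicity, read by MTT assay, with a stated time of 72 h; a higher number here means a weaker inhibitor, a lower number a stronger inhibitor. In this assay compound 2 gives 14100 nM, and compound 1 gives 6770 nM. The two differ by fluoro in place of hydrogen on an aromatic carbon, and that change produced a 2.1-fold lower number from compound 2 to compound 1 (0.32 log units; beyond the scatter). Compound 3 `Cn1cc(-c2ccccc2)cc(C(=O)Nc2ccc(Oc3ccncc3-c3cccnc3)c(F)c2)c1=O` carries an amide-linked pyridinone in place of the aminopyrimidine of compound 2; the difference between the two cores is not broken down here. In this assay compound 3 gives 9500 nM, a number within the scatter of both compound 1 and compound 2.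

Compound 4 `Cn1cc(-c2ccc(F)cc2)cc(C(=O)Nc2ccc(Oc3ccncc3-c3cccnc3)c(F)c2)c1=O` has not yet been measured. It differs from compound 3 by fluoro in place of hydrogen on an aromatic carbon. This is the same kind of change as that from compound 2 to compound 1, but not the same: in compound 1 the fluoro sits ortho to a fluoro group and meta to a large group, whereas in compound 4 it sits para to a large group, on a different core. The expectation for compound 4 rests on the step of a 2.1-fold lower number from compound 2 to compound 1 (0.32 log units; beyond the scatter), which was modest though beyond the scatter, tempered by the different place and core. Compound 4 is therefore expected to give 6000 nM in this assay. For compound 4 the estimated range runs from 2500 nM to 15000 nM. For compound 4 that expectation means a step of a 1.6-fold lower number from compound 3 to compound 4 (0.20 log units; within the scatter).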

Compound 4, half-maximal inhibitory concentration: 11900 nM
Compound 4: the middle estimate sits 2.0-fold (0.30 log units) below what was measured, and the stated range covers the measured number.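

In this assay, fluoro in place of hydrogen on an aromatic carbon, here phenyl to 4-fluorophenyl with the fluoro para to a large group, gives a 1.3-fold higher number from compound 3 to compound 4 (0.10 log units; within the scatter), so on the core of compound 3 this change has no effect that can be told from the scatter. The earlier step on the core of compound 1 did lie beyond the scatter, yet the gap between the two steps does not show that the two cores respond differently: the same change on two cores in this assay, a 2.1-fold lower number (0.32 log units; beyond the scatter) from compound 2 to compound 1 and a 1.3-fold higher number (0.10 log units; within the scatter) from compound 3 to compound 4, 2.6-fold (0.42 log units) apart, within the scatter of two such steps. This shows neither that the change carries from one core to the other nor that it fails to, since each core offers a single pair and the fluoro also sits in a different place on each, so core and place cannot be separated.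

What the compounds shown leave open is whether a chloro or methoxy group, or an amine or a carboxylic acid, on that same phenyl ring of compound 3 would give a step beyond the scatter. Also open, going by these compounds, is whether a fluoro step of either size would hold in cells other than those of this assay.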